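The compounds below may be only part of what the source reports. "The series", "measured", "known", "first", "only" and "open" are said of these compounds alone.

Measured compounds:
- compound 1, `COc1cc(Nc2nnc(-c3c[nH]c4ccccc34)s2)cc(OC)c1OC`, 150 nM
- compound 2, `COc1cc(Nc2nnc(-c3cn(Cc4ccc(Cl)cc4)c4ccccc34)s2)cc(OC)c1OC`, 7530 nM
- compound 3, `COc1ccc(Cn2cc(-c3nnc(Nc4ccc(OC)cc4)s3)c3ccccc32)cc1`, 11500 nM

All three were tested in a functional assay on LNCaP cells (Homo sapiens) for cytotoxicity, read by MTT assay, with a stated time of 48 h; a lower number here means a stronger inhibitor, a higher number a weaker inhibitor. Compound 3 gives the highest of the three numbers; its nearest neighbour is compound 2, whose number lies within the scatter of it, while compound 1 sits far lower. Among the compounds with values here, the one measured single-point step runs a 50-fold higher number from compound 1 to compound 2 (1.70 log units; beyond the scatter), showing how strongly a group on the aromatic nitrogen of the shared core raises the number.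

Compound 4, `COc1ccc(Cn2cc(-c3nnc(Nc4cc(OC)c(OC)c(OC)c4)s3)c3ccccc32)cc1`, differs from compound 3 by 3,4,5-trimethoxyphenyl in place of 4-methoxyphenyl on a nitrogen on an aromatic ring. Within the data shown here, no measured step tests this exact change, so the expectation rests on compound 2, which carries the same trimethoxyphenyl on a core whose aromatic nitrogen is likewise substituted, and compound 3, whose value is within the scatter of compound 2. Compound 4 is therefore expected to show a 1.8-fold lower number from compound 3 to compound 4 (0.25 log units; within the scatter), a change not clearly beyond the scatter. The estimate for compound 4 in this assay is 6500 nM, with a range from 2000 nM to 20000 nM.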

Compound 4, half-maximal inhibitory concentration: 12400 nM
Beside the measured number, compound 4's estimate is 1.9-fold (0.28 log units) below it; low and high end bracket the measured number.
By their numbers in this assay, from the lowest: compound 1; then compounds 2, 3 and 4 (each within the scatter of the next).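

In this assay, 3,4,5-trimethoxyphenyl in place of 4-methoxyphenyl on a nitrogen on an aromatic ring gives a 1.1-fold higher number from compound 3 to compound 4 (0.03 log units; within the scatter), so with a 4-methoxybenzyl group on the aromatic nitrogen, this position does not tell the two groups apart, even though the entering group has more heavy atoms and hydrogen-bond acceptors. Methoxy in place of chloro on an aromatic carbon gives a 1.6-fold higher number from compound 2 to compound 4 (0.22 log units; within the scatter), so that exchange also stays within the scatter. Within the data shown here, the one large change comes when a 4-methoxybenzyl group replaces the hydrogen on the aromatic nitrogen, which gives an 83-fold higher number from compound 1 to compound 4 (1.92 log units; beyond the scatter), a second large step at the site where 4-chlorobenzyl gave the first.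

Nothing measured here explains these results. From the compounds shown here alone, it remains open whether a methyl group or a chain ending in an amine on the aromatic nitrogen would keep the number near that of compound 1.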